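A few compounds are considered here, and "the series" means these few. Any claim that something is new, unique, unknown or untested is made for them only; others in the source may bear on it.

Measured compounds so far:

Compound 1, `Cc1ccnc(/C(N)=N/NC(=S)N2CCOCC2)c1`, gives 33.6% in a functional assay on A-431 cells (Homo sapiens) for cytotoxicity, read by MTT assay, with a stated time of 72 h, tested at 1 uM; on this read-out lower numbers stand for less inhibition of growth and higher numbers for more inhibition of growth at the one concentration tested.
Compound 2, `N/C(=N\NC(=S)N1CCCCC1)c1ccccn1`, gives 24.4% in this assay.

Compound 2 stands at the lower of the two numbers, with compound 1 the nearest point; the gap between the two is within the scatter of the method, so no order between them can be claimed. Among the compounds with values here, the two also differ in more than one place, and no single step between them is defined.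

The step under consideration goes from compound 2 to compound 3, `Cc1ccnc(/C(N)=N/NC(=S)N2CCCCC2)c1`. The change is methyl in place of hydrogen on an aromatic carbon; the methyl sits on an aromatic carbon of a six-membered aromatic ring with one nitrogen, opposite the ring nitrogen. Compound 1 already carries the same methyl on the same ring and lands within the scatter of compound 2, which gives no indication that this group moves the read-out by itself.

For compound 3 the step of a number 5.6 percentage points higher from compound 2 to compound 3 (within the scatter) is therefore expected to stay within the scatter, with no direction that can be relied upon. The estimate for compound 3 is 30%, with an expected range from 12% to 48%.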

Compound 3, percent growth inhibition at one concentration: 31.1%
Beside the measured number, compound 3's estimate is 1.1 percentage points below it; the range from low to high includes it.
By their numbers in this assay, from the lowest: compounds 2, 3 and 1 (each within the scatter of the next).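

The methyl in place of hydrogen on an aromatic carbon, opposite the ring nitrogen, can now be read as a single change in this assay (a number 6.7 percentage points higher from compound 2 to compound 3 (within the scatter)), and at this position the methyl cannot be told apart from hydrogen on this read-out. With the same methyl present on both compounds, piperidin-1-yl in place of morpholin-4-yl on a thiocarbonyl carbon (a number 2.5 percentage points lower from compound 1 to compound 3 (within the scatter)) likewise gives no separation, so neither of the two places has yet produced a step beyond the scatter. No supporting measurement bears on either step, so the series offers no account of them.

Whether the read-out responds to any change on this aromatic carbon remains open, since a single methyl is the only replacement for hydrogen shown and a chlorine atom, a methoxy group or a longer alkyl chain could behave differently. Within the data shown here, on the thiocarbonyl carbon, only two saturated rings are compared, which leaves open how an open-chain amine such as dimethylamino or a 4-methylpiperazin-1-yl group would read at the one concentration tested.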